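Chloro to trifluoromethyl: from compound 3 to compound 4

A few compounds are considered here, and "the series" means these few. Any claim that something is new, unique, unknown or untested is made for them only; others in the source may bear on it.

Of the compounds shown here, three so far carry numbers in an assay on CHO-K1 cells for displacement of a labelled ligand from adenosine receptor A1 (Homo sapiens), tested at 50 uM; a lower number here means less inhibition, a higher number more inhibition at the concentration tested (going by the name of the read-out). Compound 1 `Cc1sc(N)c(C(=O)c2cccs2)c1C` gives 50.3% in this assay. Compound 2 `CCOC(=O)c1nn(-c2ccc(C(C)(C)C)cc2)c(=O)c2c(N)scc12` gives 23%. Compound 3 `CCOC(=O)c1nn(-c2cccc(Cl)c2)c(=O)c2c(N)scc12` gives 100%, the highest of the three; compound 1 lies beyond the scatter below it, and compound 2 lies further below, also beyond the scatter. No two of these three differ in one place only, so no single step can be read from the measured set.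

Compound 4 `CCOC(=O)c1nn(-c2cccc(C(F)(F)F)c2)c(=O)c2c(N)scc12` is the next compound. Against compound 3 the change is trifluoromethyl in place of chloro on an aromatic carbon. The place is an aromatic carbon of a six-membered aromatic ring of carbon only, meta to a large group; the shared core of compound 3 and compound 4 is untouched. Nothing measured here speaks to this exchange directly. Since compound 3 stands at the top of the range of this assay, the step is expected to stay within the scatter or to go downward by a modest amount rather than upward. Compound 4 is estimated at 88% in this assay, within 60% to 100%. This estimate means an expected step of a number 12 percentage points lower from compound 3 to compound 4 (beyond the scatter), small and downward.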

Compound 4, a percentage reported as inhibition, at one concentration (the size of the read-out at that concentration, not a potency): 32%
The estimate for compound 4 lay 56 percentage points above the measured number, outside the stated range (below it).
By their numbers in this assay, from the lowest: compounds 2 and 4 (each within the scatter of the next); then compound 1; then compound 3.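

In this assay the series now has its first step that can be read at a single place: trifluoromethyl in place of chloro, on an aromatic carbon meta to a large group, gives a number 68 percentage points lower from compound 3 to compound 4 (beyond the scatter) with the shared core untouched. The result shows that this position is not indifferent to the substituent it carries, since this one exchange, in which 1 heavy atom leaves and 4 heavy atoms enter and no hydrogen-bond donor, hydrogen-bond acceptor, ring or net charge is involved, is enough to produce a large drop. Nothing available explains the drop.

From the compounds shown here alone, it remains open how a smaller or differently built group, such as fluoro, methoxy, an amine or a nitrile, would read at this same aromatic carbon, and whether chloro is unusual there or trifluoromethyl is. The compounds shown also leave open whether replacing the ethyl ester with a carboxylic acid or an amide would change how this position responds to the same exchange.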